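Compound 3 to compound 4: carboxy in place of iodo

The source may hold more compounds than are shown below. What is called first, only, known or untested is meant among the compounds shown, and "the series" means these compounds.

In an ADME assay on BJ cells (Homo sapiens) for cytotoxicity, with a stated time of 72 h (a lower number here means that less compound is needed, a higher number that more compound is needed for the effect), compound 1 (`COc1ccc(-c2nc3c(c(C)nn3-c3ccccc3)c(-c3ccccc3O)c2C#N)cc1`) gives > 23000 nM, which is a limit. Compound 2 (`Cc1nn(-c2ccccc2)c2nc(-c3ccccc3)c(C#N)c(-c3ccccc3O)c12`) gives > 23000 nM, also a limit. Together these two compounds stand at the limit of > 23000 nM in this assay, at which 2 of the 3 values shown sit, and neither has a number.

Compound 3 (`CCc1ccc(-c2nc3c(c(C)nn3-c3ccccc3)c(-c3ccccc3I)c2C#N)cc1`) gives > 20000 nM, again a limit. It stands at the limit of > 20000 nM in this assay, at which 1 of the 3 values shown sits, and so offers a limit, not a number, as the starting point.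

Compound 4 (`CCc1ccc(-c2nc3c(c(C)nn3-c3ccccc3)c(-c3ccccc3C(=O)O)c2C#N)cc1`) differs from compound 3 as follows: carboxy in place of iodo on an aromatic carbon. This is the change from 2-iodophenyl to 2-carboxyphenyl, on an aromatic carbon ortho to a large group.

Among the measured compounds shown here, the only measured step is a step that the two limits leave unreadable from compound 1 to compound 2, a swap of hydrogen in place of methoxy. That is a different change, and no size can be read from it. For the measured compounds named here, no measured compound carries the carboxy group, so the series gives no direct size for this swap.

With every shown value in this assay a limit, no step beyond the scatter is expected, and no direction is assigned. Expected here is a step that the limit leaves unreadable from compound 3 to compound 4 as the working assumption. A further limit is the likeliest report.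

For compound 4 the estimated value is 25000 nM with an expected range of 10000 nM to 60000 nM as the working figures.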

Compound 4, half-maximal effective concentration: > 20000 nM
Compound 4: no number, only a limit (the forecaster's own chance of this, stated with the estimate: 80%); the middle value does not contradict the limit.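

In this assay compound 3 gives > 20000 nM, which is a limit. Compound 4 gives > 20000 nM, also a limit, so no step can be read between compound 3 and compound 4. The compounds shown leave open whether carboxy in place of iodo changes the read-out at all, and at what concentration any of these compounds reaches the half-maximal effect.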